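Working notes: amide substituent change in the quinoline acid series

This account rests on a few compounds, and the source may have more. Where it says the series, first, only, none or still open, it means among the compounds named here.

Compound 2 `COc1cc(-c2cc(C(=O)O)c3ccccc3n2)ccc1OCC(=O)Nc1ccc(C(F)(F)F)cc1` stands highest of the two numbers in a physicochemical assay for lipophilicity, using the shake flask method, in phosphate buffer, measured as octanol-water partition, at pH 7.4 (on this read-out higher numbers stand for higher lipophilicity and lower numbers for lower lipophilicity), giving 1.6; compound 1 `COc1cc(-c2cc(C(=O)O)c3ccccc3n2)ccc1OCC(=O)Nc1ccccc1` gives 0.7 in this assay. Within the data shown here, the one measured step, a number 0.90 log units higher from compound 1 to compound 2 (beyond the scatter), is the only one bearing on the next change. Compound 3 `COc1cc(-c2cc(C(=O)O)c3ccccc3n2)ccc1OCC(=O)NCc1cccnc1` carries (pyridin-3-yl)methyl in place of 4-(trifluoromethyl)phenyl on an amide-type nitrogen. Among the measured compounds shown here, that step covers only the trifluoromethyl part of the exchange; the remaining change has no measured counterpart here. A drop in this assay is therefore expected, a number 1.80 log units lower from compound 2 to compound 3 (beyond the scatter), larger than the reversal of that step alone. Compound 3 is estimated at -0.2, within -1 to 0.6.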

Compound 3, distribution coefficient: -0.8
Compound 3: middle estimate off by 0.60 log units, on the high side, within the range that was stated.
By their numbers in this assay, from the lowest: compound 3; then compound 1; then compound 2.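

In this assay, the amide-type nitrogen position now moves the read-out in both directions: (pyridin-3-yl)methyl in place of 4-(trifluoromethyl)phenyl gives a number 2.40 log units lower from compound 2 to compound 3 (beyond the scatter). Loss of the trifluoromethyl group does not account for the whole drop, since (pyridin-3-yl)methyl in place of phenyl still gives a number 1.50 log units lower from compound 1 to compound 3 (beyond the scatter). No evidence available here explains the size of either step.

As far as these compounds go, the ring nitrogen and the added carbon between ring and amide nitrogen change together, so their separate contributions remain open. Benzyl or pyridin-3-yl on the same nitrogen would separate them.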